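A Smaller Group on the Ring Nitrogen

This account rests on a few compounds, and the source may have more. Where it says the series, first, only, none or still open, it means among the compounds named here.

Compound 2 `Cc1nn(C(C)(C)C)c2nc(C(C)C)c(/C=C/[C@@H](O)C[C@@H](O)CC(=O)O)c(-c3ccc(F)cc3)c12` gives 86% in an in vivo functional assay on the whole organism for inhibition of 3-hydroxy-3-methylglutaryl-coenzyme A reductase (Rattus norvegicus), at a dose of 2 mg/kg by the oral route (on this read-out lower numbers stand for a weaker effect and higher numbers for a stronger effect at the one dose given), the highest of the three numbers measured here. Compound 1 `Cc1nn(C(C)(C)C)c2nc(C3CC3)c(/C=C/[C@@H](O)C[C@@H](O)CC(=O)O)c(-c3ccc(F)cc3)c12` reaches 72.2% in this assay, and the step of a number 13.8 percentage points higher from compound 1 to compound 2 (beyond the scatter) accompanied isopropyl in place of cyclopropyl on an aromatic carbon. Compound 3 `CC(C)c1nc2cc(-c3ccccc3)nn2c(-c2ccc(F)cc2)c1/C=C/[C@@H](O)C[C@@H](O)CC(=O)O`, built on a different core, gives only 24.1% in this assay. Compound 4 `Cc1nn(C)c2nc(C(C)C)c(/C=C/[C@@H](O)C[C@@H](O)CC(=O)O)c(-c3ccc(F)cc3)c12` alters compound 2 in one place: methyl in place of tert-butyl on an aromatic nitrogen. No measured step touches this aromatic nitrogen, so the data shown give no guide to the size or direction of the change. A moderate fall, with wide uncertainty, is expected, amounting to a number 16 percentage points lower from compound 2 to compound 4 (beyond the scatter). Compound 4 is therefore estimated at 70%, between 40% and 90%.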

Compound 4, a percentage reported as inhibition, in the whole organism at one dose (the size of the read-out at that dose, not a potency): 48.1%
Compound 4: the middle estimate sits 21.9 percentage points above what was measured; the range from low to high includes it.
By their numbers in this assay, from the lowest: compound 3; then compound 4; then compound 1; then compound 2.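

The aromatic nitrogen turns out to be a sensitive position in this assay: methyl in place of tert-butyl gives a number 37.9 percentage points lower from compound 2 to compound 4 (beyond the scatter). This swap removes carbon atoms only, with no change in hydrogen-bond donors, hydrogen-bond acceptors or net charge, yet it moves the read-out more than the isopropyl for cyclopropyl swap did. Nothing available explains this fall.

For the compounds shown here, with only two groups compared on this nitrogen, it remains open how an ethyl or a cyclobutyl group would fare. A chain ending in an amine is equally untested here.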